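Halogen swap on the benzyl ring of compound 2

A few compounds are considered here, and "the series" means these few. Any claim that something is new, unique, unknown or untested is made for them only; others in the source may bear on it.

Compound 1 `O=c1c2cnn(-c3ccc(F)cc3)c2ncn1CC1(O)CCN(Cc2ccccc2Br)CC1`: 3100 nM
Compound 2 `COC(=O)c1ccc(CN2CCC(O)(Cn3cnc4c(cnn4-c4ccc(F)cc4)c3=O)CC2)c(F)c1`: 800 nM

In an assay on Sf21 cells for inhibition of ubiquitin carboxyl-terminal hydrolase 7 (Homo sapiens), read by spectrophotometry, with stated times of 30 min and 2 h (on this read-out lower numbers stand for stronger inhibition and higher numbers for weaker inhibition), compound 2 gives 800 nM, the lowest of the two numbers, while compound 1 gives 3100 nM. For the measured compounds named here, the single measured step, a 3.9-fold lower number from compound 1 to compound 2 (0.59 log units; beyond the scatter), changes the halogen and adds the methoxycarbonyl group at once, so the share of the halogen alone is not separable. Compound 3 `COC(=O)c1ccc(CN2CCC(O)(Cn3cnc4c(cnn4-c4ccc(F)cc4)c3=O)CC2)c(Br)c1` carries bromo in place of fluoro on an aromatic carbon. Going by the values given here, with no step isolating that swap, a change within the scatter is expected, as a 1.1-fold higher number from compound 2 to compound 3 (0.05 log units; within the scatter). Compound 3 is therefore estimated at 900 nM, between 400 nM and 2000 nM.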

Compound 3, half-maximal inhibitory concentration: 900 nM
Estimate against measurement, compound 3: no gap at the digits printed; low and high end bracket the measured number.
By their numbers in this assay, from the lowest: compounds 2 and 3 (each within the scatter of the next); then compound 1.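

In this assay, bromo in place of fluoro on this aromatic carbon, ortho to a large group, makes no measurable difference (a 1.1-fold higher number from compound 2 to compound 3 (0.05 log units; within the scatter)). With bromo held fixed, methoxycarbonyl in place of hydrogen accounts for a change beyond the scatter (a 3.4-fold lower number from compound 1 to compound 3 (0.54 log units; beyond the scatter)), so the gain in the earlier mixed step goes with the methoxycarbonyl group, not the halogen. No measurement at hand explains either step.

From the compounds shown here alone, whether a carboxylic acid or a primary amide can stand in for the methoxycarbonyl group remains open. So does whether chloro or hydrogen at the halogen position holds the number.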